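The compounds below may be only part of what the source reports. "The series", "measured", "known", "first", "only" and "open" are said of these compounds alone.

Three compounds measured in a toxicity assay on CCRF-CEM cells (Homo sapiens) for cytotoxicity; a higher number here means that more compound is tolerated, a lower number that less compound is tolerated:

Compound 1, `CNc1cccc2c1nc(-c1c(F)cccc1F)n2Cc1c(F)cccc1F`: 27.2 uM
Compound 2, `O=C(O)c1cccc2c1nc(-c1c(F)cccc1F)n2Cc1c(F)cccc1F`: 23.5 uM
Compound 3, `[N-]=[N+]=NCc1cccc2c1nc(-c1c(F)cccc1F)n2Cc1c(F)cccc1F`: > 100 uM

Compound 1 stands highest of the two numbers given, with compound 2 nearest; the step of a 1.2-fold lower number from compound 1 to compound 2 (0.06 log units; within the scatter) lies within the scatter, so the two are not told apart. Compound 3 reaches only a limit of the assay, (the limit of > 100 uM in this assay, at which 1 of the 3 values shown sits), and not a number. The step of an at least 3.6-fold higher number from compound 1 to compound 3 (0.56 log units; beyond the scatter) is beyond the scatter, as is an at least 4.2-fold higher number from compound 2 to compound 3 (0.62 log units; beyond the scatter).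

Compound 4, `CC(=O)NCc1cccc2c1nc(-c1c(F)cccc1F)n2Cc1c(F)cccc1F`, has not yet been measured in this assay. It differs from compound 1 in one place: acetamidomethyl in place of methylamino on an aromatic carbon. Among the measured compounds shown here, no measured step carries exactly this change. The step of a 1.2-fold lower number from compound 1 to compound 2 (0.06 log units; within the scatter) shows that one exchange at this carbon left the number unmoved, while an at least 3.6-fold higher number from compound 1 to compound 3 (0.56 log units; beyond the scatter) shows that another, to a methylene-linked group, raised it beyond the scatter. The acetamidomethyl group of compound 4 is likewise carried on a methylene, so a modest rise from compound 1 is expected, though not one pressing against the limit. The expected step is a 1.7-fold higher number from compound 1 to compound 4 (0.22 log units; within the scatter). Compound 4 is therefore estimated at 45 uM, within a range from 20 uM to 100 uM.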

Compound 4, half-maximal toxic concentration: 20.8 uM
Beside the measured number, compound 4's estimate is 2.2-fold (0.34 log units) above it, and the stated range covers the measured number.
By their numbers in this assay, from the lowest: compounds 4, 2 and 1 (each within the scatter of the next). At a limit, above all of these: compound 3.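

In this assay, a methylene on the aromatic carbon does not by itself raise the number: the acetamidomethyl group of compound 4 cannot be told apart from the methylamino group of compound 1 (a 1.3-fold lower number from compound 1 to compound 4 (0.12 log units; within the scatter)) or from the carboxy group of compound 2 (a 1.1-fold lower number from compound 2 to compound 4 (0.05 log units; within the scatter)). On the saturated chain carbon itself, the exchange of azido for acetamido does move the number beyond the scatter (an at least 4.8-fold lower number from compound 3 to compound 4 (0.68 log units; beyond the scatter)), so among these four compounds the tolerance stands with the azidomethyl group of compound 3 alone, while the three other groups, different as they are, give values within the scatter of one another. The value of compound 3 is a limit of the assay and not a number: (the limit of > 100 uM in this assay, at which 1 of the 4 values shown sits).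

As far as these compounds go, whether an aminomethyl or a hydroxymethyl group on this aromatic carbon would side with compound 3 or with compound 4 stays open. Also open, from the compounds shown here alone, are how far compound 3 lies past its limit and whether a longer chain ending in azido would stay at that limit.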